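Adding a (3-fluorobenzyl)oxy group at the site of compound 2

The source may report more compounds than this note shows. Statements on the series, on what has been measured and on what is new or still open speak of the compounds shown alone.

Compound 1 `NS(=O)(=O)c1ccc(NC(=S)Nc2ccc3ncnc(Nc4ccc(F)c(Cl)c4)c3c2)cc1`: 37600 nM
Compound 2 `NS(=O)(=O)c1ccc(NC(=S)Nc2ccc3ncnc(Nc4cccc(Cl)c4)c3c2)cc1`: 15000 nM

Of the compounds shown here, two on a shared core have been measured in a functional assay on A-431 cells (Homo sapiens) for antiproliferative activity, read by MTT assay, with a stated time of 72 h; on this read-out higher numbers stand for weaker inhibition and lower numbers for stronger inhibition. In this assay compound 1 gives 37600 nM and compound 2 gives 15000 nM. Between them lies a 2.5-fold lower number from compound 1 to compound 2 (0.40 log units; beyond the scatter). Compound 2 therefore stands lowest of the two numbers, with compound 1 as its nearest neighbour at a higher number.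

Compound 3 `NS(=O)(=O)c1ccc(NC(=S)Nc2ccc3ncnc(Nc4ccc(OCc5cccc(F)c5)c(Cl)c4)c3c2)cc1` differs from compound 2 in one place: (3-fluorobenzyl)oxy in place of hydrogen on an aromatic carbon, the new group sitting ortho to a chloro group and para to a large group. Going by the values given here, the only measured step touching this position is a 2.5-fold lower number from compound 1 to compound 2 (0.40 log units; beyond the scatter), in which a small change there moved the number modestly but beyond the scatter. Among the compounds with values here, no measured step covers the entry of a group of this size, so the estimate rests on that single modest step and carries a wide range. Compound 3 is expected to give 8000 nM in this assay, within 2000 nM to 30000 nM. The expected step is a 1.9-fold lower number from compound 2 to compound 3 (0.27 log units; within the scatter).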

Compound 3, half-maximal inhibitory concentration: 29500 nM
Estimate against measurement, compound 3: 3.7-fold (0.57 log units) below; measured number inside the range.
By their numbers in this assay, from the lowest: compounds 2, 3 and 1 (each within the scatter of the next, the first and the last beyond it).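

In this assay, the entry of (3-fluorobenzyl)oxy in place of hydrogen gives a 2.0-fold higher number from compound 2 to compound 3 (0.29 log units; within the scatter), so this position, on an aromatic carbon ortho to a chloro group and para to a large group, takes a group of this size with no shift beyond the scatter. Set against fluoro at the same carbon, the same group gives a 1.3-fold lower number from compound 1 to compound 3 (0.11 log units; within the scatter), which places the large group within the scatter of both smaller substituents, even though those two are themselves separated by a 2.5-fold lower number from compound 1 to compound 2 (0.40 log units; beyond the scatter). Nothing available bears on why the numbers fall this way.

The compounds shown place only hydrogen, fluoro and (3-fluorobenzyl)oxy at this carbon, so it remains open how an amine, a carboxylic acid, a methoxy group or a longer alkoxy chain would stand there. It is also open whether the fluorine on the benzyl ring contributes anything to the number, as the unsubstituted benzyloxy group is not among these compounds.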